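A Methyl on an Aromatic Nitrogen: What to Expect

The source may hold more compounds than are shown below. What is called first, only, known or untested is meant among the compounds shown, and "the series" means these compounds.

The series centres on compound 2, `O=C(Nc1ccc(Oc2ccnc3[nH]ccc23)cc1)c1nn(-c2ccc(Cl)c(C(F)(F)F)c2)ccc1=O`, which in a functional assay on HepG2 cells (Homo sapiens) for cytotoxicity, read by MTT assay, with a stated time of 72 h (a higher number here means a weaker inhibitor, a lower number a stronger inhibitor), gives 1320 nM. Among the three measured compounds it holds the lowest number: compound 1, `O=C(Nc1ccc(Oc2ccnc3[nH]ccc23)cc1)c1nn(-c2ccc(Cl)c(F)c2)ccc1=O`, gives 5240 nM, and compound 3, `O=C(Nc1ccc(Oc2ccnc3[nH]ccc23)c(F)c1)c1nn(-c2ccc(Cl)c(C(F)(F)F)c2)ccc1=O`, gives 11900 nM. The two measured steps both lie beyond the scatter: a 4.0-fold lower number from compound 1 to compound 2 (0.60 log units; beyond the scatter), and a 9.0-fold higher number from compound 2 to compound 3 (0.95 log units; beyond the scatter).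

Compound 4, `Cn1ccc2c(Oc3ccc(NC(=O)c4nn(-c5ccc(Cl)c(C(F)(F)F)c5)ccc4=O)cc3)ccnc21`, differs from compound 2 by methyl in place of hydrogen on an aromatic nitrogen. Neither measured step touches this part of the molecule: the step from compound 1 to compound 2 alters the aryl attached to the pyridazinone, and the step from compound 2 to compound 3 alters the central phenyl. Nothing in the measured set therefore speaks directly to a change on the aromatic nitrogen of the five-membered ring, and the account can only note that the two known changes, one a modest gain and one a modest loss, were both of moderate size.

Compound 4 is therefore expected to land close to compound 2, with the estimate 2000 nM and a range from 600 nM to 7000 nM. The implied step, a 1.5-fold higher number from compound 2 to compound 4 (0.18 log units; within the scatter), is expected to stay within or only slightly beyond the scatter.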

Compound 4, half-maximal inhibitory concentration: 23400 nM
Beside the measured number, compound 4's estimate is 12-fold (1.07 log units) below it, and the stated range ends below it.
By their numbers in this assay, from the lowest: compound 2; then compound 1; then compounds 3 and 4 (each within the scatter of the next).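

In this assay, the aromatic nitrogen of the five-membered ring proves to be a position where even a single added carbon matters: methyl in place of hydrogen gives an 18-fold higher number from compound 2 to compound 4 (1.25 log units; beyond the scatter), a large step. This one-atom change moves the number further than either earlier change, the modest steps being a 4.0-fold lower number from compound 1 to compound 2 (0.60 log units; beyond the scatter) on the aryl attached to the pyridazinone and a 9.0-fold higher number from compound 2 to compound 3 (0.95 log units; beyond the scatter) on the central phenyl, so the nitrogen hydrogen cannot be treated as a freely replaceable part of compound 2. The data show the size and direction of this step but offer no measurement that would explain it.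

The compounds shown leave open whether the change in number tracks the size of the group on this nitrogen, as an ethyl or a longer chain ending in a hydroxyl or an amine might show, or whether any replacement of the hydrogen has a similar result. They also leave open whether methyl on this nitrogen would give a step of similar size with a fluoro on the central phenyl or with a fluoro in place of the trifluoromethyl on the outer aryl.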